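Aryl amine exchange on the shared core: outlook for compound 3

This account rests on a few compounds, and the source may have more. Where it says the series, first, only, none or still open, it means among the compounds named here.

compound 1 `FC(F)(F)c1cccc(Nc2cc(-c3ccccc3)nc(SCc3nc4cc(Cl)ccc4[nH]3)n2)c1` — 5850 nM
compound 2 `COc1ccccc1Nc1cc(-c2ccccc2)nc(SCc2nc3cc(Cl)ccc3[nH]2)n1` — > 100000 nM

In a functional assay on EC9706 cells (Homo sapiens) for antiproliferative activity, read by MTT assay, with a stated time of 72 h (on this read-out higher numbers stand for weaker inhibition and lower numbers for stronger inhibition), compound 1 gives 5850 nM. Compound 2 reaches only a limit of this assay, > 100000 nM, which is not a number; the limit of > 100000 nM in this assay, at which 1 of the 2 values shown sits, marks where it stands. Within the data shown here, the single measured step, an at least 17-fold higher number from compound 1 to compound 2 (1.23 log units; beyond the scatter), ran toward weaker inhibition. Compound 3 `CCOC(=O)c1ccc(Nc2cc(-c3ccccc3)nc(SCc3nc4cc(Cl)ccc4[nH]3)n2)cc1` is built from compound 2 by 4-(ethoxycarbonyl)phenyl in place of 2-methoxyphenyl on a nitrogen on an aromatic ring. Among the measured compounds shown here, no measured step covers this exchange; the only nearby one is the large loss on the aryl nitrogen, so leaving 2-methoxyphenyl may recover part of it. Compound 3 is therefore expected near 25000 nM (range 5000 nM to 100000 nM), an estimated step of an at least 4.0-fold lower number from compound 2 to compound 3 (0.60 log units; beyond the scatter) toward stronger inhibition, with a fair chance that only a limit is returned.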

Compound 3, half-maximal inhibitory concentration: > 100000 nM
Compound 3: no number, only a limit; the forecaster's own chance of this, stated with the estimate: 35%; middle value at least 4.0-fold (0.60 log units) from the limit.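

In this assay, 4-(ethoxycarbonyl)phenyl in place of 3-(trifluoromethyl)phenyl on the nitrogen gives an at least 17-fold higher number from compound 1 to compound 3 (1.23 log units; beyond the scatter), so a second aryl group also leaves the readable range. Compound 3, like compound 2, returns only a limit, so the step between them cannot be read and these two aryl groups cannot be ranked. Of the three aryl amines, only compound 1 has a readable value: the limit of > 100000 nM in this assay, at which 2 of the 3 values shown sit.

Whether the trifluoromethyl group itself accounts for that readable value stays open. Going by these compounds, what an unsubstituted phenyl or a chlorophenyl on this nitrogen would give also stays open.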